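Ethoxy to methoxy step carried across two cores

This account rests on a few compounds, and the source may have more. Where it says the series, first, only, none or still open, it means among the compounds named here.

Measured compounds, with their numbers in an ADME assay on Vero cells (Chlorocebus sabaeus) for cytotoxicity, read by cytopathic effect, with a stated time of 48 h; on this read-out higher numbers stand for lower toxicity in this test and lower numbers for higher toxicity in this test:

compound 1 `CO/N=C1/CCN(c2c(F)cc3c(=O)c(C(=O)O)cn(C4CC4)c3c2F)CC1(C)CN` — compound 1 gives 88.4 ug/mL
compound 2 `CCO/N=C1/CCN(c2nc3c(cc2F)c(=O)c(C(=O)O)cn3C2CC2)CC1(C)CN` — compound 2 gives 44.2 ug/mL
compound 3 `CCO/N=C1/CCN(c2c(F)cc3c(=O)c(C(=O)O)cn(C4CC4)c3c2F)CC1(C)CN` — compound 3 gives 62.5 ug/mL

Compound 3 and compound 1 share a core and differ in one place: hydrogen in place of methyl on a saturated chain carbon bound to an oxygen on an unsaturated carbon. The step of a 1.4-fold higher number from compound 3 to compound 1 (0.15 log units; within the scatter) is small, so this change leaves the read-out in this assay essentially where it was on that core.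

Compound 2 carries a different core from compound 3; the difference between the two cores is not broken down here. Of the three numbers, compound 2 has the lowest, but its gaps to compound 3 and to compound 1 both lie within the scatter, so no order among the three is claimed.

Compound 4 `CO/N=C1/CCN(c2nc3c(cc2F)c(=O)c(C(=O)O)cn3C2CC2)CC1(C)CN` is not yet measured. It stands to compound 2 as compound 1 stands to compound 3: hydrogen in place of methyl on a saturated chain carbon bound to an oxygen on an unsaturated carbon. The place is the same in both pairs, so this is the same change made on the other core.

Among the compounds with values here, the expectation for compound 4 rests on the only measured instance of the change, a 1.4-fold higher number from compound 3 to compound 1 (0.15 log units; within the scatter), applied to the value of compound 2, 44.2 ug/mL. On that basis the step is expected to be a 1.3-fold higher number from compound 2 to compound 4 (0.12 log units; within the scatter), a change that would again sit within the scatter. Compound 4 is therefore estimated at 58 ug/mL in this assay, with a plausible range from 30 ug/mL to 110 ug/mL.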

Compound 4, half-maximal cytotoxic concentration: 177 ug/mL
For compound 4 the middle estimate is 3.1-fold (0.48 log units) below the measured one; measured number above the stated range.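

In this assay, the change from ethoxy to methoxy on the second core gives a 4.0-fold higher number from compound 2 to compound 4 (0.60 log units; beyond the scatter), a modest step that can be read as a real shift towards lower toxicity in this test on that core. The size of this step therefore does not carry over from one core to the other, and a step taken from one core would not have predicted the size of the step on the other: the same change on two cores in this assay, a 1.4-fold higher number (0.15 log units; within the scatter) from compound 3 to compound 1 and a 4.0-fold higher number (0.60 log units; beyond the scatter) from compound 2 to compound 4, 2.8-fold (0.45 log units) apart, beyond the scatter of two such steps What this does not show is which feature of the two cores sets the difference, since the cores are not broken down here and each contributes a single matched pair, so no general rule for this change across the series can be drawn from these compounds.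

From the compounds shown here alone, whether a longer chain such as propoxy, or a benzyloxy group, in the same place would follow the larger step seen on the core of compound 4 or the small one seen on the core of compound 1 remains open. Also open, going by these compounds, is whether an amine or a carboxylic acid at the end of that chain would keep the two cores apart in the same way.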